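The source may report more compounds than this note shows. Statements on the series, on what has been measured and on what is new or still open speak of the compounds shown alone.

Read-out in an ADME assay on PBMC cells (Homo sapiens) for cytotoxicity, with a stated time of 5 days; a lower number here means a stronger inhibitor, a higher number a weaker inhibitor:
- compound 1 `CC(C)(CO)Nc1nc(N)nc2c1ncn2[C@H]1C[C@H](N=[N+]=[N-])[C@@H](CO)O1`: limit > 100000 nM
- compound 2 `CC(CO)Nc1nc(N)nc2c1ncn2[C@H]1C[C@H](N=[N+]=[N-])[C@@H](CO)O1`: limit > 100000 nM
- compound 3 `[N-]=[N+]=N[C@H]1C[C@H](n2cnc3c(NCCO)nc(N)nc32)O[C@@H]1CO`: limit > 100000 nM

Compound 3 stands at a limit, not a number, > 100000 nM. The whole series sits there, (the limit of > 100000 nM in this assay, at which 3 of the 3 values shown sit). The measured steps give no size: a step that the two limits leave unreadable from compound 1 to compound 2, a step that the two limits leave unreadable from compound 1 to compound 3 and a step that the two limits leave unreadable from compound 2 to compound 3.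

Compound 4 `C=CCN(C)c1nc(N)nc2c1ncn2[C@H]1C[C@H](N=[N+]=[N-])[C@@H](CO)O1` carries allyl(methyl)amino in place of (2-hydroxyethyl)amino on an aromatic carbon, (allyl(methyl)amino in place of (2-hydroxyethyl)amino on an aromatic carbon). Going by the values given here, no measured compound carries this group, so no measured size transfers to it. The only anchor is the limit of compound 3 at > 100000 nM. The expected outcome is a number no higher from compound 3 to compound 4 (the limit leaves the size open), with no step beyond the scatter and no firm direction in this assay. For compound 4 the estimate is 100000 nM, with an expected range from 30000 nM to 200000 nM, and another limit is likely.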

Compound 4, half-maximal inhibitory concentration: > 100000 nM
Compound 4 was reported as a limit; the forecaster's own chance of this, stated with the estimate: 75%; the middle value lies on the limit itself.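

In this assay, going by these compounds alone, compound 4 gives > 100000 nM, a limit, so no step from compound 1, compound 2 or compound 3 to compound 4 can be read. The compounds shown leave open whether any of these amino groups on the shared core changes the read-out at all: the limit of > 100000 nM in this assay, at which 4 of the 4 values shown sit.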